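Working notes: isopropyl in place of cyclohexylmethyl

This account rests on a few compounds, and the source may have more. Where it says the series, first, only, none or still open, it means among the compounds named here.

Compound 1 `COC[C@H](NC(=O)c1cc(OC)no1)C(=O)N[C@@H](COC)C(=O)N[C@@H](CC(C)C)C(=O)[C@@]1(C)CO1`: 82 nM
Compound 2 `COC[C@H](NC(=O)c1cc(C)on1)C(=O)N[C@@H](CC1CCCCC1)C(=O)N[C@@H](CC(C)C)C(=O)[C@@]1(C)CO1`: 353 nM

In a functional assay on MES-SA cells (Homo sapiens) for cytotoxicity, read by luminescence and CellTiter-Glo, with a stated time of 72 h (on this read-out higher numbers stand for weaker inhibition and lower numbers for stronger inhibition), compound 2 gives 353 nM, the higher of the two numbers and so the weaker inhibition. Compound 1 gives 82 nM, and this gap lies beyond the scatter. The two compounds differ in more than one place, so their gap isolates no single change.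

Compound 3 `COC[C@H](NC(=O)c1cc(C)on1)C(=O)N[C@H](C(=O)N[C@@H](CC(C)C)C(=O)[C@@]1(C)CO1)C(C)C` has isopropyl in place of cyclohexylmethyl on a saturated chain carbon bound to an amide-type nitrogen and a carbonyl carbon. Among the compounds with values here, no measured pair shows this change alone, so the expectation in this assay is tentative. A moderate move to a lower number is expected, and it may not clear the scatter. Within the data shown here, the only guide is the lower number of compound 1, 82 nM. The estimated step is a 2.1-fold lower number from compound 2 to compound 3 (0.32 log units; beyond the scatter). For compound 3 the expected value is 170 nM, with an estimated range of 60 nM to 450 nM.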

Compound 3, half-maximal inhibitory concentration: 636 nM
Beside the measured number, compound 3's estimate is 3.7-fold (0.57 log units) below it; measured number above the stated range.
By their numbers in this assay, from the lowest: compound 1; then compounds 2 and 3 (each within the scatter of the next).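

In this assay, within the data shown here, isopropyl in place of cyclohexylmethyl on a saturated chain carbon bound to an amide-type nitrogen and a carbonyl carbon gives a 1.8-fold higher number from compound 2 to compound 3 (0.26 log units; within the scatter), the first reading of a single change. At this place, cyclohexylmethyl and isopropyl therefore cannot be told apart in this assay, and the six-membered ring of carbon is not required to keep the number at the level of compound 2. No supporting measurement is available to explain this reading.

As far as these compounds go, whether an aminomethyl group, a carboxylic acid or a longer chain such as n-hexyl at this place would shift the number beyond the scatter stays open. From the compounds shown here alone, the share of this place in the lower number of compound 1 also stays open, since compound 1 differs from compound 2 in more than one place.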